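A few compounds are considered here, and "the series" means these few. Any claim that something is new, unique, unknown or untested is made for them only; others in the source may bear on it.

Measured compounds:
compound 1, `CNC(=O)c1cc(C(=O)NCCCC2CNCCO2)cn(Cc2ccccc2)c1=O`: >= 194 ug/mL
compound 2, `CNC(=O)c1cc(C(=O)NC2CCC2)cn(Cc2cccnc2)c1=O`: >= 99 ug/mL
compound 3, `CNC(=O)c1cc(C(=O)NC2CC2)cn(Cc2cccc3cc[nH]c23)c1=O`: >= 144 ug/mL

In a physicochemical assay for solubility (on this read-out higher numbers stand for higher solubility and lower numbers for lower solubility), compound 3 gives >= 144 ug/mL, which is a limit of the assay rather than an exact number. Compound 1 also sits at a limit, (the limit of >= 194 ug/mL in this assay, at which 1 of the 3 values shown sits). Compound 2 sits at a limit as well, (the limit of >= 99 ug/mL in this assay, at which 1 of the 3 values shown sits). Every value is a limit. Among the measured compounds shown here, no step between the three can be sized, and all that can be said is that each reaches its limit. Compound 4, `CNC(=O)c1cc(C(=O)NC2CC2)cn(Cc2cccc(C)c2)c1=O`, differs from compound 3 in one place: 3-methylphenyl in place of 1H-indol-7-yl on a saturated chain carbon bound to an aromatic nitrogen. For the measured compounds named here, with no measured step to lean on, the expected change in this assay is small and downward, an at least 1.4-fold lower number from compound 3 to compound 4 (0.15 log units; that floor lies within the scatter), quite possibly within the scatter. Compound 4 is expected to give about 100 ug/mL, within 30 ug/mL to 300 ug/mL.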

Compound 4, solubility: >= 205 ug/mL
Compound 4: a limit, no number; the forecaster's own chance of this, stated with the estimate: 45%; middle value at least 2.0-fold (0.31 log units) away from the limit.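

Compound 3 and compound 4 both sit at limits in this assay, and the step between them cannot be read. The compounds shown leave open the exact number for each compound, and whether 3-methylphenyl in place of 1H-indol-7-yl shifts the read-out at all.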